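A few compounds are considered here, and "the series" means these few. Any claim that something is new, unique, unknown or untested is made for them only; others in the source may bear on it.

Compound 1 `O=C(CSc1nnc(-c2ccncc2)o1)N/N=C/c1cc(Cl)ccc1O` and compound 2 `O=C(CSc1nnc(-c2ccncc2)o1)N/N=C/c1cc(Br)cc(Br)c1O` share the same core and differ only in the ring attached to the carbon with a double bond to nitrogen. In a functional assay on MCF7 cells (Homo sapiens) for cytotoxicity, read by MTT assay, with a stated time of 48 h (a higher number here means a weaker inhibitor, a lower number a stronger inhibitor), compound 1 gives 5830 nM, and compound 2 gives 9010 nM. The step of a 1.5-fold higher number from compound 1 to compound 2 (0.19 log units; within the scatter) shows that swapping the halogen pattern on the hydroxyphenyl ring made no clear difference. Among the compounds with values here, compound 2 stands as one of only two measured numbers, and its nearest neighbour, compound 1, lies within the scatter of it.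

Compound 3 `O=C(CSc1nnc(-c2ccncc2)o1)N/N=C/c1cccs1` carries a smaller, sulfur-containing ring in that place: thiophen-2-yl in place of 3,5-dibromo-2-hydroxyphenyl on a carbon with a double bond to nitrogen. Within the data shown here, the only measured step that touches this position is the one from compound 1 to compound 2, and it stayed within the scatter; no measured step replaces the hydroxyphenyl ring itself, so the data give little guidance. The expectation is therefore a step of about a 1.0-fold lower number from compound 2 to compound 3 (0.00 log units; within the scatter), not clearly beyond the scatter, with a wide range. Compound 3 is estimated at 9000 nM, between 3000 nM and 30000 nM in this assay.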

Compound 3, half-maximal inhibitory concentration: 23500 nM
Compound 3: the middle estimate sits 2.6-fold (0.42 log units) below what was measured, within the range that was stated.
By their numbers in this assay, from the lowest: compounds 1 and 2 (each within the scatter of the next); then compound 3.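

Replacing the hydroxyphenyl ring altogether does what changing its halogens did not: in this assay, thiophen-2-yl in place of 3,5-dibromo-2-hydroxyphenyl gives a 2.6-fold higher number from compound 2 to compound 3 (0.42 log units; beyond the scatter) and thiophen-2-yl in place of 5-chloro-2-hydroxyphenyl gives a 4.0-fold higher number from compound 1 to compound 3 (0.61 log units; beyond the scatter) so that compound 3 is the weakest of the three. The position on the carbon with a double bond to nitrogen therefore does respond to what it carries, and both steps, though modest, point the same way, even though the two halogenated hydroxyphenyl rings could not be told apart. This single swap changes several things at once, including the ring size, the number of heavy atoms and the hydrogen-bond donor count, and no supporting data are available to show which of these accounts for the weaker result.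

Within the data shown here, with only one ring lacking the hydroxyl group, the effect of that group cannot be separated from the effect of the ring itself. As far as these compounds go, how a plain phenyl ring, a ring bearing an amine or a carboxylic acid, or a longer chain would behave at this position remains open.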